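A few compounds are considered here, and "the series" means these few. Any claim that something is new, unique, unknown or untested is made for them only; others in the source may bear on it.

In an ADME assay on S9 fraction from liver (Rattus norvegicus) for metabolic stability, read by LC-MS, using NADPH, with a stated time of 30 min (a higher number here means that more of the compound is left, a lower number that less of the compound is left), three compounds that share one core have been measured. Compound 1 `CCCCCCCCc1ccc(OCC(=O)Cn2nnc(-c3ccccc3Cl)n2)cc1` gives 28%, compound 2 `CCCCCCCCc1ccc(OCC(=O)Cn2nnc(-c3cccc(C(=O)OC)c3)n2)cc1` gives 19% and compound 3 `CCCCCCCCc1ccc(OCC(=O)Cn2nnc(-c3cccc(S(=O)(=O)N(C)C)c3)n2)cc1` gives 9%. Where compound 3 stands follows from two steps: a number 10 percentage points lower from compound 2 to compound 3 (within the scatter), and a number 19 percentage points lower from compound 1 to compound 3 (beyond the scatter).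

Compound 4 `CCCCCCCCc1ccc(OCC(=O)Cn2nnc(Cc3ccccc3)n2)cc1` differs from compound 3 on an aromatic carbon of the five-membered aromatic ring, with benzyl in place of 3-(dimethylsulfamoyl)phenyl (benzyl in place of 3-(dimethylsulfamoyl)phenyl on an aromatic carbon). For the measured compounds named here, no measured step covers this exact exchange. The nearest evidence comes from the other exchanges at this carbon, which add a number 9 percentage points lower from compound 1 to compound 2 (within the scatter) to the two steps above. All three are modest or smaller, so a step of similar size is expected here. With compound 3 at 9%, little room remains downward, so the expected direction is upward. The estimated step is a number 8 percentage points higher from compound 3 to compound 4 (within the scatter), which would be no clear departure from the scatter. Compound 4 is expected at 17%, with an estimated range from 5% to 32%.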

Compound 4, percent of the compound remaining: < 5%
Compound 4 ended at the assay's limit (the forecaster's own chance of this, stated with the estimate: 5%); at least 12 percentage points between middle value and limit.
By their numbers in this assay, from the lowest: compounds 3, 2 and 1 (each within the scatter of the next, the first and the last beyond it). At a limit, below all of these: compound 4.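

In this assay compound 4 gives < 5%, which is a limit of the assay and not a number: the limit of < 5% in this assay, at which 1 of the 4 values shown sits. Even so, benzyl on this aromatic carbon separates clearly from two of the earlier groups, with a number at least 14 percentage points lower from compound 2 to compound 4 (beyond the scatter) and a number at least 23 percentage points lower from compound 1 to compound 4 (beyond the scatter). Against the third, a number at least 4 percentage points lower from compound 3 to compound 4 (that floor lies within the scatter), so compound 4 cannot be placed apart from compound 3, and a group of carbon only thus stands at the low end of this series together with 3-(dimethylsulfamoyl)phenyl.

The compounds shown leave open how a plain phenyl or a pyridine at this carbon would compare with benzyl. They also leave open whether a shorter chain in place of the alkyl chain, or an alcohol in place of the carbonyl, would leave more of the compound.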